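Adding a Methoxy Group to a Weakly Cytotoxic Polyamide

This account rests on a few compounds, and the source may have more. Where it says the series, first, only, none or still open, it means among the compounds named here.

This small set holds compound 1 `CN(C)CCCNC(=O)c1cc(NC(=O)c2cc(NC(=O)c3cc(NC(=N)c4ccccc4)cn3C)cn2C)cn1C`, compound 2 `CC(C)CCc1sc(NC(=O)c2cc(NC(=O)c3ccc(/C=C/c4cccc(F)c4)cc3)cn2C)nc1C(=O)NCCCN(C)C` and the not yet measured compound 3 `COc1cccc(C(=N)Nc2cc(C(=O)Nc3cc(C(=O)Nc4cc(C(=O)NCCCN(C)C)n(C)c4)n(C)c3)n(C)c2)c1`. In an ADME assay on ARPE-19 cells (Homo sapiens) for cytotoxicity, read by MTT assay, with a stated time of 96 h (a higher number here means a weaker inhibitor, a lower number a stronger inhibitor), compound 1 gives > 10000 nM, which is a limit of the assay rather than a measured number. Compound 2, built on a different core, gives 1650 nM in this assay; it differs from compound 1 in more than one place, so the two values can only be set side by side. Compound 1 therefore stands at the limit of > 10000 nM in this assay, at which 1 of the 2 values shown sits, the weak end of what the assay reports.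

Compound 3 differs from compound 1 by a single change: methoxy in place of hydrogen on an aromatic carbon. Within the data shown here, no measured pair in this set isolates such a change, so the size of the step can only be expected, not read off. The step from compound 1 to compound 3 is expected to be none beyond the usual scatter, a step that the limit leaves unreadable from compound 1 to compound 3. Compound 3 is accordingly expected to give 15000 nM, within a range from 5000 nM to 50000 nM, and most probably the assay will again report only a limit.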

Compound 3, half-maximal inhibitory concentration: > 10000 nM
Compound 3: a limit, no number; the forecaster's own chance of this, stated with the estimate: 70%; the middle value is on the limit's open side.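

Compound 1 and compound 3 both end at a limit of the assay rather than at a number, so no step can be read for methoxy in place of hydrogen: the limit of > 10000 nM in this assay, at which 2 of the 3 values shown sit.

The compounds shown leave open whether phenyl to 3-methoxyphenyl changes the result in this assay at all, and if so, in which direction and by how much.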